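This account rests on a few compounds, and the source may have more. Where it says the series, first, only, none or still open, it means among the compounds named here.

Working notes on the series, all of which share one core and vary only the aryl group on an amide-type nitrogen. In a functional assay on MDA-MB-231 cells (Homo sapiens) for cytotoxicity, read by MTT assay, with a stated time of 48 h (a lower number here means a stronger inhibitor, a higher number a weaker inhibitor), compound 1 (`O=C(NCCCCC(c1ccc(F)cc1)c1ccc(F)cc1)Nc1ccc(C(F)(F)F)cc1`) gives 2780 nM. Compound 2 (`Cc1cccc(NC(=O)NCCCCC(c2ccc(F)cc2)c2ccc(F)cc2)c1`) reads > 20000 nM, which is a limit of the assay and not a number. Compound 3 (`Nc1cc(NC(=O)NCCCCC(c2ccc(F)cc2)c2ccc(F)cc2)ccc1Cl`) gives 9240 nM, the higher of the two true numbers in this assay.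

Next is compound 4 (`O=C(NCCCCC(c1ccc(F)cc1)c1ccc(F)cc1)Nc1ccc([N+](=O)[O-])c(Cl)c1`), with 3-chloro-4-nitrophenyl in place of 3-amino-4-chlorophenyl on the same amide-type nitrogen: 3-chloro-4-nitrophenyl in place of 3-amino-4-chlorophenyl on an amide-type nitrogen. Chlorine stays on the ring, the hydrogen-bond donor goes, and the nitrogen-bearing group is larger.

All three measured steps change the aryl group at this place. They are an at least 7.1-fold higher number from compound 1 to compound 2 (0.85 log units; beyond the scatter), a 3.3-fold higher number from compound 1 to compound 3 (0.52 log units; beyond the scatter) and an at least 2.1-fold lower number from compound 2 to compound 3 (0.33 log units; beyond the scatter), so replacing this group has moved the number beyond the scatter each time, though none of the compounds carries a nitro group. The room for improvement is set by compound 1, given a 3.3-fold higher number from compound 1 to compound 3 (0.52 log units; beyond the scatter), so a modest fall in this assay is expected rather than a large one in either direction. The expected change is a 2.1-fold lower number from compound 3 to compound 4 (0.31 log units; beyond the scatter). For compound 4 the estimated value is 4500 nM, with an expected range of 1500 nM to 14000 nM.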

Compound 4, half-maximal inhibitory concentration: 3470 nM
Compound 4: the middle estimate sits 1.3-fold (0.11 log units) above what was measured; measured number inside the range.
By their numbers in this assay, from the lowest: compounds 1 and 4 (each within the scatter of the next); then compound 3. At a limit, above all of these: compound 2.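

In this assay, replacing 3-amino-4-chlorophenyl with 3-chloro-4-nitrophenyl on the amide-type nitrogen gives a 2.7-fold lower number from compound 3 to compound 4 (0.43 log units; beyond the scatter), so a nitro-bearing aryl group with no hydrogen-bond donor is compatible with a reading lower than that of the amino-bearing one. Set against the best-placed earlier group, the same aryl change gives a 1.2-fold higher number from compound 1 to compound 4 (0.10 log units; within the scatter), so 3-chloro-4-nitrophenyl and 4-(trifluoromethyl)phenyl cannot be told apart in this assay, and a second, quite different group now reaches the level that compound 1 alone held before. The gain over 3-methylphenyl, an at least 5.7-fold lower number from compound 2 to compound 4 (0.76 log units; beyond the scatter), is only a bound, since compound 2 stands at a limit of the assay and not at a number: the limit of > 20000 nM in this assay, at which 1 of the 4 values shown sits.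

Compounds 3 and 4 differ in more than one feature of the aryl group, so the compounds shown do not separate the loss of the amino group from the entry of the nitro group, or show what the chlorine contributes. Also open, as far as these compounds go, is whether a plain 4-nitrophenyl, a nitrile or a carboxylic acid at this place would read like compounds 1 and 4 or fall away towards compound 3.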